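This account rests on a few compounds, and the source may have more. Where it says the series, first, only, none or still open, it means among the compounds named here.

Measured compounds:

Compound 1, `COc1cccc(Sc2c[nH]c3ccc(Cl)cc23)c1`: 21000 nM
Compound 2, `COc1ccccc1Sc1c[nH]c2ccc(I)cc12`: 45000 nM
Compound 3, `COc1cc(OC)cc(Sc2c[nH]c3ccc(Cl)cc23)c1`: 7000 nM

These three compounds were tested in an assay on isolated protein for inhibition of Indoleamine 2,3-dioxygenase 1 (Homo sapiens), read by HPLC, with a stated time of 60 min, in the presence of a further agent that is not named here; on this read-out lower numbers stand for stronger inhibition and higher numbers for weaker inhibition. Compound 3 gives the lowest number of the three: compound 1 sits a 3.0-fold lower number from compound 1 to compound 3 (0.48 log units; beyond the scatter) away, and the values of compound 3 and compound 2 lie further apart still. For the measured compounds named here, the single step between compounds that differ in one place, from compound 1 to compound 3, is a 3.0-fold lower number from compound 1 to compound 3 (0.48 log units; beyond the scatter) and comes from a methoxy in place of hydrogen on an aromatic carbon.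

Compound 4, `COc1cc(OC)cc(Sc2c(C)[nH]c3ccc(Cl)cc23)c1`, has not yet been measured. It differs from compound 3 by methyl in place of hydrogen on an aromatic carbon, the change sitting on an aromatic carbon of a five-membered aromatic ring with one nitrogen, part of a fused system of two rings, next to the ring nitrogen and next to the ring atom that bears a large group. Going by the values given here, no measured step touches this part of the shared core, so nothing among the three compounds bears directly on it; the only measured step concerns a different ring. With no guidance, the expected step of a 1.1-fold higher number from compound 3 to compound 4 (0.06 log units; within the scatter) is taken as none beyond the scatter in this assay. Compound 4 is therefore estimated at 8000 nM, within a range from 2500 nM to 25000 nM.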

Compound 4, half-maximal inhibitory concentration: 45000 nM
Compound 4: middle estimate off by 5.6-fold (0.75 log units), on the low side; measured number above the stated range.
By their numbers in this assay, from the lowest: compound 3; then compound 1; then compounds 2 and 4 (each within the scatter of the next).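

In this assay, a methyl in place of hydrogen on the aromatic carbon of the five-membered ring, next to the ring nitrogen and next to the ring atom that bears a large group, gives a 6.4-fold higher number from compound 3 to compound 4 (0.81 log units; beyond the scatter) and so moves the number clearly upward. This shows that the shared core is not indifferent at this position: even a group of 1 heavy atom, with no hydrogen-bond donors or acceptors and no net charge, changes the result beyond the scatter. For the compounds shown here, the only earlier step, a 3.0-fold lower number from compound 1 to compound 3 (0.48 log units; beyond the scatter), concerned a different ring and went the other way, so this is the first measured change that weakens inhibition, and no information at hand accounts for it.

The compounds shown leave open how other groups at this position would behave, such as a fluorine atom, a longer chain like ethyl, an amine or a carboxylic acid. They also leave open whether the same methyl would raise the number to a similar degree on the core of compound 1, which carries one methoxy rather than two.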